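A Second Aryl Amide Variation on a Weak Phenyl Analogue

The source may report more compounds than this note shows. Statements on the series, on what has been measured and on what is new or still open speak of the compounds shown alone.

Three compounds share one core and differ at two places. Compound 1 `O=C(CN1CCN(c2nnc(Cc3ccncc3)c3ccccc23)CC1)Nc1ccc(F)c(Cl)c1` carries a pyridin-4-yl group on the saturated chain carbon and a 3-chloro-4-fluorophenyl group on the amide nitrogen; in a functional assay on MDA-MB-231 cells (Homo sapiens) for cytotoxicity, read by MTT assay, with a stated time of 72 h (a higher number here means a weaker inhibitor, a lower number a stronger inhibitor), compound 1 gives 4 nM. Compound 3 `O=C(CN1CCN(c2nnc(Cc3ccccc3)c3ccccc23)CC1)Nc1ccc(F)c(Cl)c1` keeps the amide group but has phenyl instead of pyridin-4-yl, and compound 3 gives 7360 nM, a step of a 1800-fold higher number from compound 1 to compound 3 (3.26 log units; beyond the scatter). Compound 2 `COc1ccc(NC(=O)CN2CCN(c3nnc(Cc4ccccc4)c4ccccc34)CC2)cc1OC` pairs that phenyl with a 3,4-dimethoxyphenyl on the amide nitrogen, and compound 2 gives 32200 nM. Compound 3 thus stands second highest of the three numbers, nearest to compound 2 and far from compound 1; the step is a 4.4-fold lower number from compound 2 to compound 3 (0.64 log units; beyond the scatter).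

Compound 4 `O=C(CN1CCN(c2nnc(Cc3ccccc3)c3ccccc23)CC1)Nc1c(F)cccc1F` alters the amide-side ring once more: 2,6-difluorophenyl in place of 3-chloro-4-fluorophenyl on an amide-type nitrogen. For the measured compounds named here, the only measured step on the amide-type nitrogen, a 4.4-fold lower number from compound 2 to compound 3 (0.64 log units; beyond the scatter), was modest, and no measured pair tests a fluorine-only ring there, so a modest shift in this assay is expected, direction uncertain. Compound 4 is estimated at 10000 nM, between 3000 nM and 40000 nM. The step this estimate implies, a 1.4-fold higher number from compound 3 to compound 4 (0.13 log units; within the scatter), is expected to be modest.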

Compound 4, half-maximal inhibitory concentration: 5490 nM
Compound 4: the middle estimate sits 1.8-fold (0.26 log units) above what was measured; measured number inside the range.
By their numbers in this assay, from the lowest: compound 1; then compounds 4 and 3 (each within the scatter of the next); then compound 2.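

Replacing 3-chloro-4-fluorophenyl with 2,6-difluorophenyl on the amide-type nitrogen gives a 1.3-fold lower number from compound 3 to compound 4 (0.13 log units; within the scatter), so in this assay, with phenyl on the chain carbon, these two halogen-bearing rings cannot be told apart, even though the chlorine is gone and the fluorines sit elsewhere on the ring. Compound 2 stays separate from both, and the step to the second of them is a 5.9-fold lower number from compound 2 to compound 4 (0.77 log units; beyond the scatter), so the 3,4-dimethoxyphenyl ring, not one particular halogen pattern, is what stands apart among these phenyl compounds. Nothing measured here explains this difference.

Whether 2,6-difluorophenyl would work alongside pyridin-4-yl, the group in compound 1, remains open, as every amide-side comparison shown has phenyl on the chain carbon. Also open, on these data alone, is how a plain phenyl, or a ring bearing an amine or a carboxylic acid, would read on that nitrogen.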